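The source may report more compounds than this note shows. Statements on the series, on what has been measured and on what is new or still open speak of the compounds shown alone.

Compound 1 `CC1=CC[C@H](C(C)(C)NC(=S)NN)CC1`: 200 nM
Compound 2 `CC1=CC[C@H](C(C)(C)NC(=S)N/N=C/c2ccccc2)CC1`: 26300 nM

In a functional assay on U-251 cells (Homo sapiens) for inhibition, read by sulforhodamine B assay, with a stated time of 48 h (on this read-out higher numbers stand for weaker inhibition of growth and lower numbers for stronger inhibition of growth), compound 1 holds the lowest of the two numbers, and compound 2 sits far higher, well beyond the scatter. Compound 3 `CC1=CC[C@H](C(C)(C)NC(=S)N/N=C/c2ccc[nH]2)CC1` departs from compound 1 by a group of 7 heavy atoms (5 carbon, 2 nitrogen; one five-membered aromatic ring with 1 hetero atom) in place of one nitrogen atom, on an amide-type nitrogen, a change of the same kind that separates compound 2 from compound 1. Since compound 2 gives 26300 nM against 200 nM for compound 1, a large step toward weaker growth inhibition is expected, roughly a 75-fold higher number from compound 1 to compound 3 (1.88 log units; beyond the scatter) in this assay. Compound 3 is therefore estimated at 15000 nM, within a range of 3000 nM to 60000 nM.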

Compound 3, concentration for 50% growth inhibition: 80 nM
Compound 3: the middle estimate sits 190-fold (2.27 log units) above what was measured; the measured number lies below the stated range.
By their numbers in this assay, from the lowest: compound 3; then compound 1; then compound 2.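

In this assay, a group of 7 heavy atoms on the amide-type nitrogen need not weaken growth inhibition: a 2.5-fold lower number from compound 1 to compound 3 (0.40 log units; beyond the scatter) is a modest step toward stronger inhibition, so the loss seen with compound 2 does not extend to every such replacement. On a carbon with a double bond to nitrogen, 1H-pyrrol-2-yl in place of phenyl gives a 330-fold lower number from compound 2 to compound 3 (2.52 log units; beyond the scatter), showing that the outcome here depends strongly on the ring carried. No available evidence accounts for this difference.

The compounds shown leave open whether the ring nitrogen with its hydrogen matters, which a furan-2-yl or 1-methylpyrrol-2-yl group would test. Going by these compounds, it also remains open whether a pyridin-2-yl ring would track with phenyl or with 1H-pyrrol-2-yl.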